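From bromo to methoxy on the shared core

The compounds below may be only part of what the source reports. "The series", "measured", "known", "first", "only" and "open" are said of these compounds alone.

Compound 1 `Cn1cc(C2CC(c3ccccc3)=NN2C(=O)c2cccnc2)c2ccccc21`: > 10000 nM (a limit)
Compound 2 `Cn1cc(C2CC(c3ccccc3)=NN2C(=O)c2cccnc2)c2cc(Br)ccc21`: 1600 nM
Compound 3 `COc1ccc(C2=NN(C(=O)c3cccnc3)C(c3cn(C)c4ccc(Br)cc34)C2)cc1OC`: 2380 nM

In a functional assay on A549 cells (Homo sapiens) for inhibition, read by MTT assay, with a stated time of 48 h (on this read-out lower numbers stand for stronger inhibition of growth and higher numbers for weaker inhibition of growth), compound 2 gives 1600 nM and lies within the scatter of compound 3 at 2380 nM so the two cannot be ranked. Compound 1 gives > 10000 nM as a limit of the assay, not a number.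

Compound 4 `COc1ccc2c(c1)c(C1CC(c3ccccc3)=NN1C(=O)c1cccnc1)cn2C` carries methoxy in place of bromo on an aromatic carbon and is otherwise the same as compound 2. The nearest guide is an at least 6.2-fold lower number from compound 1 to compound 2 (0.79 log units; beyond the scatter) where the size rests on the limit of > 10000 nM in this assay, at which 1 of the 3 values shown sits, and is only a minimum. The other measured step, a 1.5-fold higher number from compound 2 to compound 3 (0.17 log units; within the scatter), changes a different place and stays within the scatter. Among the compounds with values here, no measured compound carries methoxy at this carbon, so a moderately higher number is expected, with only part of the gain from bromo kept. The estimated change is a 2.2-fold higher number from compound 2 to compound 4 (0.34 log units; beyond the scatter) in this assay as a rough guide. Compound 4 is expected at 3500 nM with an estimated range from 1200 nM to 10000 nM in this read-out.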

Compound 4, concentration for 50% growth inhibition: > 10000 nM
Compound 4: no number, only a limit (the forecaster's own chance of this, stated with the estimate: 20%); middle value at least 2.8-fold (0.45 log units) from the limit.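

Placing methoxy on this aromatic carbon in place of bromo gives an at least 6.2-fold higher number from compound 2 to compound 4 (0.79 log units; beyond the scatter) in this assay, so the gain seen with bromo does not carry over to any group at this carbon. Of the three groups shown here (hydrogen, bromo and methoxy), only bromo gives a readable number, in compound 2 and compound 3. Compound 4, like compound 1, gives only a limit, so the step between them cannot be read: the limit of > 10000 nM in this assay, at which 2 of the 4 values shown sit.

As far as these compounds go, how chloro, methyl or an amine at this carbon would compare remains open. Any of them could fall on either side of bromo.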